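Aryl Exchange on an Aromatic Nitrogen: Compound 2 to Compound 3

This account rests on a few compounds, and the source may have more. Where it says the series, first, only, none or still open, it means among the compounds named here.

Compound 1 `N#Cc1ccc(-n2nc(-c3ccc(C(F)(F)F)cc3O)nc2-c2ccccc2O)cc1`: 86.8%
Compound 2 `Oc1cc(C(F)(F)F)ccc1-c1nc(-c2ccccc2O)n(-c2cccc(F)c2)n1`: 87.7%

Both compounds were tested in a functional assay on PC-12 cells (Rattus norvegicus) for cytotoxicity, read by MTT assay, with stated times of 2 h and 24 h, tested at 5 uM; on this read-out higher numbers stand for a stronger effect at the one concentration tested and lower numbers for a weaker effect. Among the measured compounds shown here, the two numbers sit together: the only one-place step measured, a number 0.9 percentage points higher from compound 1 to compound 2 (within the scatter), leaves compound 2 no further from compound 1 than repeated runs of this kind usually differ, so the two cannot be told apart on these data.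

Compound 3 `Oc1cc(C(F)(F)F)ccc1-c1nc(-c2ccccc2O)n(-c2ccc(F)cc2F)n1` has not yet been measured. It differs from compound 2 by 2,4-difluorophenyl in place of 3-fluorophenyl on an aromatic nitrogen. For the measured compounds named here, the one measured step that bears on this change is the earlier aryl exchange on an aromatic nitrogen, a number 0.9 percentage points higher from compound 1 to compound 2 (within the scatter), which was within the scatter. Accordingly, in this assay a step no larger than the scatter is expected, with no direction. Compound 3 is therefore estimated to give about 87%, in a range of 75% to 96%. The step this estimate means, a number 0.7 percentage points lower from compound 2 to compound 3 (within the scatter), is expected to stay within the scatter.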

Compound 3, a percentage reported as activity, at one concentration (the size of the read-out at that concentration, not a potency): 83.5%
Compound 3: the middle estimate sits 3.5 percentage points above what was measured; low and high end bracket the measured number.
By their numbers in this assay, from the lowest: compounds 3, 1 and 2 (each within the scatter of the next).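

With a third aryl group on the aromatic nitrogen, the numbers in this assay still cannot be told apart: the result is a number 4.2 percentage points lower from compound 2 to compound 3 (within the scatter) and, against the nitrile-bearing aryl group, a number 3.3 percentage points lower from compound 1 to compound 3 (within the scatter) as well. Across these three compounds, then, 4-cyanophenyl, 3-fluorophenyl and 2,4-difluorophenyl give numbers that the assay does not separate, so the second fluorine of compound 3 brings no step beyond the scatter, and no compound here goes against that reading. No measurement at hand accounts for these numbers.

The compounds shown leave open whether any group on this nitrogen can move the number beyond the scatter, since all three carry a substituted phenyl ring. A carboxylic acid or an amine on that ring, or a longer alkyl chain in its place, remains the open test.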